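A few compounds are considered here, and "the series" means these few. Any claim that something is new, unique, unknown or untested is made for them only; others in the source may bear on it.

In a functional assay on the whole organism with Rattus norvegicus as the target (on this read-out lower numbers stand for an effect already at smaller amounts and higher numbers for an effect only at larger amounts of compound), compound 2 `Cc1cccc(C)c1NN=C1CCC(C)n2c1ncc(C(=O)O)c2=O` gives 320 umol/kg. Compound 3 `Cc1cc(C)c(NN=C2CCC(C)n3c2ncc(C(=O)O)c3=O)c(C)c1` gives 320 umol/kg, so compound 2 stands level with compound 3 at the digits shown, and the step of no change at the digits printed from compound 2 to compound 3 (within the scatter). Compound 1 `CC1CCC(=NNc2ccccc2C(=O)O)c2ncc(C(=O)NO)c(=O)n21` sits at the limit of > 100 umol/kg in this assay, at which 1 of the 3 values shown sits; its value > 100 umol/kg is a limit of the assay and not a number. Compound 4 `CC1CCC(=NNc2ccc(Br)cc2Cl)c2ncc(C(=O)O)c(=O)n21` differs from compound 2 by 4-bromo-2-chlorophenyl in place of 2,6-dimethylphenyl on an amine nitrogen. Within the data shown here, the one measured step, from compound 2 to compound 3, concerns a methyl on an aromatic carbon and stays within the scatter; no measured step exchanges the whole phenyl group or introduces a halogen, so nothing here argues for a move in either direction. The step of no change at the digits printed from compound 2 to compound 4 (within the scatter) is therefore expected to stay within the scatter, with a wide range to reflect the missing evidence. Compound 4 is expected to give 320 umol/kg in this assay, between 120 umol/kg and 900 umol/kg.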

Compound 4, dose for 50% inhibition: > 100 umol/kg
Compound 4 ended at the assay's limit; the forecaster's own chance of this, stated with the estimate: 20%; the middle value lies beyond the limit too.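

In this assay, compound 4 gives > 100 umol/kg, which is a limit of the assay and not a number, so its step from compound 2 cannot be read. The compounds shown leave open whether 4-bromo-2-chlorophenyl in place of 2,6-dimethylphenyl changes the effect at all, and in which direction.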